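Working notes: compound 4 against three inactive analogues

The compounds below may be only part of what the source reports. "The series", "measured", "known", "first", "only" and "open" are said of these compounds alone.

Measured so far in a functional assay on HL-60 cells (Homo sapiens), read by calcium flux; a higher number here means that more compound is needed for the effect, a lower number that less compound is needed:
compound 1 `COc1cccc(Cc2cc(C3CCCCC3)nn(CC(=O)Nc3ccc(Br)cc3)c2=O)c1`: > 50000 nM
compound 2 `COc1ccc(Cc2cc(-c3ccc(Cl)cc3)nn(CC(=O)Nc3ccc(Br)cc3)c2=O)cc1`: > 50000 nM
compound 3 `Cc1cc(Cc2cccc(Cl)c2)c(=O)n(CC(=O)Nc2ccc(Br)cc2)n1`: > 50000 nM

Compound 3 gives only a limit in this assay, not a number, and that limit is the limit of > 50000 nM in this assay, at which 3 of the 3 values shown sit. Compound 1 gives only a limit as well. Compound 2 likewise gives only a limit. For the measured compounds named here, nothing among the three measured compounds separates one from another, so no step between them can be sized. Compound 4 `Cc1cc(Cc2ccc(C(N)=O)cc2)c(=O)n(CC(=O)Nc2ccc(Br)cc2)n1` differs from compound 3 by 4-carbamoylphenyl in place of 3-chlorophenyl on a saturated chain carbon bound to an aromatic carbon. Going by the values given here, with no measured step to lean on, no change beyond the scatter is expected in this assay, and another limit is the likeliest outcome. The estimate for compound 4 is 60000 nM, ranging from 15000 nM to 250000 nM, which corresponds to an expected step that the limit leaves unreadable from compound 3 to compound 4.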

Compound 4, half-maximal effective concentration: > 50000 nM
Compound 4 was reported as a limit; the forecaster's own chance of this, stated with the estimate: 85%; the middle value does not contradict the limit.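

Compound 3 and compound 4 both give only a limit, so no new step can be read between them: the limit of > 50000 nM in this assay, at which 4 of the 4 values shown sit.

The compounds shown leave open whether any change on the shared core yields a measurable value in this assay.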